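Working notes: from compound 3 to compound 4

A few compounds are considered here, and "the series" means these few. Any claim that something is new, unique, unknown or untested is made for them only; others in the source may bear on it.

Measured so far in a functional assay on HepG2 cells (Homo sapiens) for cytotoxicity, read by MTT assay, with a stated time of 48 h; on this read-out lower numbers stand for stronger inhibition and higher numbers for weaker inhibition
- compound 1 `Cc1ccc(/C=C2/S/C(=N/c3ccccc3)N(Cc3ccncc3)C2=O)cc1` gives 19700 nM
- compound 2 `CC(C)c1ccc(/C=C2/S/C(=N/c3ccccc3)N(Cc3ccncc3)C2=O)cc1` gives 32300 nM
- compound 3 `COc1ccc(OC)c(/C=C2/S/C(=N/c3ccccc3)N(Cc3ccncc3)C2=O)c1` gives 35800 nM

Compound 3 stands at 35800 nM within the scatter of compound 1 and compound 2, so no order can be read among the three. Compound 4 `O=C1/C(=C\c2cccc(Cl)c2)S/C(=N/c2ccccc2)N1Cc1ccncc1` has not been measured. Its structure differs from that of compound 3 by 3-chlorophenyl in place of 2,5-dimethoxyphenyl on a double-bonded chain carbon bound to a double-bonded ring carbon with 3-chlorophenyl in place of 2,5-dimethoxyphenyl. Two measured steps alter the group at this place, a 1.8-fold higher number from compound 1 to compound 3 (0.26 log units; within the scatter) and a 1.1-fold higher number from compound 2 to compound 3 (0.04 log units; within the scatter) and neither leaves the scatter. The step of a 1.6-fold higher number from compound 1 to compound 2 (0.21 log units; within the scatter) on an aromatic carbon also stays within it. Going by the values given here, no measured compound carries 3-chlorophenyl. No step beyond the scatter is expected in this assay for this change. The expected step is a 1.4-fold lower number from compound 3 to compound 4 (0.14 log units; within the scatter) with its direction left open. Compound 4 is estimated at 26000 nM with an expected range from 11000 nM to 58000 nM for this measurement.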

Compound 4, half-maximal inhibitory concentration: 28900 nM
Compound 4: middle estimate off by 1.1-fold (0.05 log units), on the low side; low and high end bracket the measured number.
By their numbers in this assay, from the lowest: compounds 1, 4, 2 and 3 (each within the scatter of the next).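

In this assay, 3-chlorophenyl on a double-bonded chain carbon bound to a double-bonded ring carbon gives no step beyond the scatter against any of the earlier groups (a 1.2-fold lower number from compound 3 to compound 4 (0.09 log units; within the scatter); a 1.1-fold lower number from compound 2 to compound 4 (0.05 log units; within the scatter); a 1.5-fold higher number from compound 1 to compound 4 (0.17 log units; within the scatter)). So this place also tolerates a chlorine-bearing ring without hydrogen-bond acceptors, in place of 2,5-dimethoxyphenyl, which carries them, with no order emerging among the four compounds. No evidence is available to explain this flat result.

Whether any group at this place can leave the scatter stays open, since the compounds shown carry only methyl, isopropyl, methoxy or chlorine on the phenyl ring. From the compounds shown here alone, an amine or a carboxylic acid on that ring remains untested ground.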